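Arylamide Variation at the Amide Nitrogen and Paw Edema

The compounds below may be only part of what the source reports. "The series", "measured", "known", "first", "only" and "open" are said of these compounds alone.

Measured compounds:
compound 1, `CN(C)CCNC(=O)c1c(O)c2cccnc2n(-c2ccccc2)c1=O`, 18.4%
compound 2, `O=C(Nc1ccccc1)c1c(O)c2cccnc2n(-c2ccccc2)c1=O`, -15%
compound 3, `Nc1ccc(NC(=O)c2c(O)c3cccnc3n(-c3ccccc3)c2=O)cc1`, 0%

The three measured compounds share one core and differ only in the group on the amide-type nitrogen. In a functional assay on the whole organism for inhibition, with Rattus norvegicus as the target, read by cytopathic effect and paw edema, at a dose of 100 mg/kg by the oral route (a lower number here means less inhibition, a higher number more inhibition at the dose given (going by the name of the read-out)), compound 3 stands second highest of the three numbers: the step of a number 15 percentage points higher from compound 2 to compound 3 (beyond the scatter) places it above compound 2, while the step of a number 18.4 percentage points lower from compound 1 to compound 3 (beyond the scatter) leaves it clearly below compound 1.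

Compound 4, `O=C(Nc1cccc([N+](=O)[O-])c1)c1c(O)c2cccnc2n(-c2ccccc2)c1=O`, is reached from compound 3 by the change (3-nitrophenyl in place of 4-aminophenyl on an amide-type nitrogen). Among the compounds with values here, two measured steps bear on it. The step of a number 33.4 percentage points lower from compound 1 to compound 2 (beyond the scatter) and the step of a number 18.4 percentage points lower from compound 1 to compound 3 (beyond the scatter) both show that an aromatic ring on the amide-type nitrogen gives a lower number than 2-(dimethylamino)ethyl, so compound 4, which also carries an aromatic ring there, is expected to sit in the region of compound 2 and compound 3. Within the data shown here, the step of a number 15 percentage points higher from compound 2 to compound 3 (beyond the scatter) shows that a substituent on that ring can shift the number modestly, but no measured step tests a nitro group, so its direction is unknown. For compound 4 the expected step is therefore a number 5 percentage points lower from compound 3 to compound 4 (within the scatter), not beyond the scatter, and compound 4 is estimated at -5% with a range from -25% to 15%.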

Compound 4, a percentage reported as inhibition, in the whole organism at one dose (the size of the read-out at that dose, not a potency): 7.4%
Compound 4: the middle estimate sits 12.4 percentage points below what was measured; the range from low to high includes it.
By their numbers in this assay, from the lowest: compound 2; then compounds 3 and 4 (each within the scatter of the next); then compound 1.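

In this assay, 3-nitrophenyl in place of 4-aminophenyl on the amide-type nitrogen gives a number 7.4 percentage points higher from compound 3 to compound 4 (within the scatter), so these two groups cannot be told apart here, although they differ in both the substituent and its place on the ring. Nitro in place of hydrogen on the phenyl ring gives a number 22.4 percentage points higher from compound 2 to compound 4 (beyond the scatter), so amino is no longer the only ring substituent shown to go with a number above that of the unsubstituted phenyl. Against the non-aromatic side chain, 3-nitrophenyl in place of 2-(dimethylamino)ethyl gives a number 11 percentage points lower from compound 1 to compound 4 (beyond the scatter), so each of the three aromatic groups shown on this nitrogen gives a lower number than 2-(dimethylamino)ethyl.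

Nothing given here explains any of these differences. Still open, from the compounds shown here alone, are whether 3-aminophenyl and 4-nitrophenyl would separate the effect of the substituent from that of its place on the ring, and whether a carboxylic acid on the phenyl ring or a longer chain ending in dimethylamino would reach or pass the number of compound 1.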